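The source may report more compounds than this note shows. Statements on the series, on what has been measured and on what is new or still open speak of the compounds shown alone.

In an assay on HEK293 cells for displacement of a labelled ligand from Melanocortin receptor 4 (Homo sapiens) (a lower number here means a stronger inhibitor, a higher number a weaker inhibitor), the first compound, compound 1 `CCCCC(N)c1cc(C(F)(F)F)ccc1N1CCN(C(=O)CCc2ccc(Cl)cc2Cl)CC1`, gives 190 nM. Compound 2 `CCC(C)C(N)c1cc(C(F)(F)F)ccc1N1CCN(C(=O)CCc2ccc(Cl)cc2Cl)CC1` differs from it only in the side chain on the carbon that bears the amine, and in this assay compound 2 gives 160 nM. That step, a 1.2-fold lower number from compound 1 to compound 2 (0.07 log units; within the scatter), is the only one measured here between two compounds that differ in a single place, and it does not move the number beyond the scatter.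

Compound 3 `CC(C)C[C@H](N)c1cc(C(F)(F)F)ccc1N1CCN(C(=O)CCc2ccc(O)cc2)CC1` is another matter. In this assay compound 3 reaches only the limit > 10000 nM, so no number is known for it, only that it lies at the limit (the limit of > 10000 nM in this assay, at which 1 of the 3 values shown sits).

The new compound, compound 4 `CC(C)C[C@H](N)c1cc(C(F)(F)F)ccc1N1CCN(C(=O)CCc2cn(C)c3ccccc23)CC1`, is built from compound 3 with one change: 1-methyl-1H-indol-3-yl in place of 4-hydroxyphenyl on a saturated chain carbon, two bonds along the chain from a carbonyl carbon. For the measured compounds named here, no measured step in this set touches that end of the chain, so the one measured step, on the amine side, gives no direct guidance. What the numbers do show is that compound 1 and compound 2, which carry a different group at this same position, give numbers in the assay while compound 3 gives a limit. On that basis a large change is expected, and the estimated step of an at least 6.6-fold lower number from compound 3 to compound 4 (0.82 log units; beyond the scatter) points towards stronger binding. Compound 4 is therefore expected to give about 1500 nM, somewhere between 200 nM and 10000 nM.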

Compound 4, inhibition constant: 3000 nM
Beside the measured number, compound 4's estimate is 2.0-fold (0.30 log units) below it; the range from low to high includes it.
By their numbers in this assay, from the lowest: compounds 2 and 1 (each within the scatter of the next); then compound 4. At a limit, above all of these: compound 3.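

In this assay, for the compounds shown here, replacing 4-hydroxyphenyl with 1-methyl-1H-indol-3-yl gives an at least 3.3-fold lower number from compound 3 to compound 4 (0.52 log units; beyond the scatter), the first direct evidence that the group on this saturated chain carbon, two bonds along the chain from a carbonyl carbon, can move the number beyond the scatter. Going by these compounds alone, the single step changes several things at once: the entering group has two aromatic rings where the leaving group has one, and 0 hydrogen-bond donors where the leaving group has 1, so the step cannot show which of these differences matters. Compound 3 stands at a limit and not at a number, so the full size of the step stays unknown: the limit of > 10000 nM in this assay, at which 1 of the 4 values shown sits.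

The compounds shown leave open how a plain phenyl ring with no hydroxyl, or 1H-indol-3-yl with a hydrogen in place of the methyl on the ring nitrogen, would read at this position, and such groups could help separate those differences. From the compounds shown here alone, it also remains open whether the 1-methyl-1H-indol-3-yl group would give a step of similar size with the butyl or sec-butyl side chains of compound 1 and compound 2 on the amine-bearing carbon.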